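Title: From neopentyl to 4-methylphenyl on the shared core

The source may report more compounds than this note shows. Statements on the series, on what has been measured and on what is new or still open speak of the compounds shown alone.

Among the three measured compounds, compound 3 `CC(C)(C)CCc1cnc(CCc2ccc(-c3ccccc3C(=O)O)cc2)[nH]1` gives the lowest number in an in vitro functional assay on cells for agonist activity at Bombesin receptor subtype-3 (Mus musculus), read by luminescence and calcium flux (a lower number here means that less compound is needed, a higher number that more compound is needed for the effect), namely 6.2 nM. Compound 1 `Cc1ccccc1Cc1cnc(CCc2ccc(-c3ccccc3C(=O)O)cc2)[nH]1` gives 9.3 nM in this assay, and the step of a 1.5-fold lower number from compound 1 to compound 3 (0.18 log units; within the scatter) lies within the scatter. Compound 2 `COc1ccc(Cc2cnc(CCc3ccc(-c4ccccc4C(=O)O)cc3)[nH]2)cc1` gives 513 nM, and the step of an 83-fold lower number from compound 2 to compound 3 (1.92 log units; beyond the scatter) is a large one.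

Compound 4 `Cc1ccc(Cc2cnc(CCc3ccc(-c4ccccc4C(=O)O)cc3)[nH]2)cc1` differs from compound 3 in one place: 4-methylphenyl in place of neopentyl on a saturated chain carbon bound to an aromatic carbon. Going by the values given here, two measured steps bear on this change. The step of a 1.5-fold lower number from compound 1 to compound 3 (0.18 log units; within the scatter) shows that an aryl group carrying a methyl can match neopentyl here, whereas the step of an 83-fold lower number from compound 2 to compound 3 (1.92 log units; beyond the scatter) shows that an aryl group carrying a methoxy falls far behind it. Compound 4 carries a methyl, like compound 1, but as 4-methylphenyl rather than 2-methylphenyl, so the outcome is uncertain and a moderately higher number seems the most likely, the step being estimated as a 9.7-fold higher number from compound 3 to compound 4 (0.99 log units; beyond the scatter). Compound 4 is therefore expected to give about 60 nM in this assay, within a range of 8 nM to 500 nM.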

Compound 4, half-maximal effective concentration: 162 nM
Compound 4: middle estimate off by 2.7-fold (0.43 log units), on the low side, and the stated range covers the measured number.
By their numbers in this assay, from the lowest: compounds 3 and 1 (each within the scatter of the next); then compound 4; then compound 2.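

In this assay the two methyl-bearing aryl groups do not behave alike: the change from 2-methylphenyl to 4-methylphenyl is a 17-fold higher number from compound 1 to compound 4 (1.24 log units; beyond the scatter) and the match with neopentyl seen for compound 1 does not carry over to the other methyl isomer, as a 26-fold higher number from compound 3 to compound 4 (1.42 log units; beyond the scatter) makes clear. Methyl in place of methoxy on an aromatic carbon gives only a modest step, a 3.2-fold lower number from compound 2 to compound 4 (0.50 log units; beyond the scatter) so among these compounds the place of the substituent on the aryl group goes with a large step, and the choice between these two substituents with a smaller one. No available evidence accounts for these differences.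

The compounds shown leave open whether an unsubstituted phenyl or a chlorine on that ring would give a number closer to that of compound 1 or that of compound 2. They also leave open how a longer chain in place of neopentyl would compare.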